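Swapping the triazole nitrogen substituent from benzyl to cyclobutyl

A few compounds are considered here, and "the series" means these few. Any claim that something is new, unique, unknown or untested is made for them only; others in the source may bear on it.

Of the compounds shown here, three sharing one core have been measured in a functional assay on RAW264.7 cells (Mus musculus) for inhibition, read by Griess assay, with stated times of 2 h and 24 h; a lower number here means a stronger inhibitor, a higher number a weaker inhibitor. Compound 1 `COc1ccc([C@@H]2CC(=O)c3c(O)cc(OCc4cn(Cc5ccccc5C#N)nn4)cc3O2)cc1O` gives 14600 nM. Compound 2 `COc1ccc([C@@H]2CC(=O)c3c(O)cc(OCc4cn(C5CCCC5)nn4)cc3O2)cc1O` gives 10500 nM. Compound 3 `COc1ccc([C@@H]2CC(=O)c3c(O)cc(OCc4cn(Cc5ccccc5)nn4)cc3O2)cc1O` gives 11000 nM, the second highest of the three numbers; its nearest neighbour is compound 2 and its furthest is compound 1, and both gaps lie within the scatter, so the three compounds cannot be ranked.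

Compound 4 `COc1ccc([C@@H]2CC(=O)c3c(O)cc(OCc4cn(C5CCC5)nn4)cc3O2)cc1O` has not been measured. It differs from compound 3 in one place: cyclobutyl in place of benzyl on an aromatic nitrogen. The step that bears on this is the one that exchanged cyclopentyl for benzyl on the same aromatic nitrogen, a 1.0-fold higher number from compound 2 to compound 3 (0.02 log units; within the scatter), which was flat; the related step of a 1.4-fold lower number from compound 1 to compound 2 (0.14 log units; within the scatter) also lay within the scatter. Since a saturated ring and a benzyl group at this position gave the same number, the smaller cyclobutyl ring is expected to behave alike, and the step of no change at the digits printed from compound 3 to compound 4 (within the scatter) is expected to stay within the scatter. Compound 4 is therefore estimated at 11000 nM, with a range from 5500 nM to 22000 nM.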

Compound 4, half-maximal inhibitory concentration: 15300 nM
The estimate for compound 4 lay 1.4-fold (0.14 log units) below the measured number; the range from low to high includes it.
By their numbers in this assay, from the lowest: compounds 2, 3, 1 and 4 (each within the scatter of the next).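

In this assay, the position now holds a third kind of group: a four-membered non-aromatic ring of carbon only replaces a six-membered aromatic ring, with a 1.4-fold higher number from compound 3 to compound 4 (0.14 log units; within the scatter). The same cyclobutyl group, set against the other two substituents, gives a 1.5-fold higher number from compound 2 to compound 4 (0.16 log units; within the scatter) and a 1.0-fold higher number from compound 1 to compound 4 (0.02 log units; within the scatter), so all of the steps to the new compound stay within the scatter and the four compounds cannot be ranked. Nothing available explains this flat response at the aromatic nitrogen.

From the compounds shown here alone, whether any group on this nitrogen can move the number beyond the scatter remains open, for example an amine, a carboxylic acid or a longer alkyl chain. The compounds shown also leave open whether changes elsewhere on the shared core would have a larger effect.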